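The source may report more compounds than this note shows. Statements on the series, on what has been measured and on what is new or still open speak of the compounds shown alone.

Compound 2 `CC(C)(C)OC(=O)N(Cc1ccco1)C(=O)c1ccc(Cn2sc3ccccc3c2=O)cc1` and compound 1 `O=C(c1ccc(Cn2sc3ccccc3c2=O)cc1)N1CCCCC1` share a core and were both tested in an ADME assay on RAW264.7 cells (Mus musculus) for cytotoxicity, read by WST assay; on this read-out higher numbers stand for lower toxicity in this test and lower numbers for higher toxicity in this test. For compound 1 the assay reports only a limit, > 100000 nM. For compound 2 the reading is likewise a limit, > 100000 nM. Compound 2 thus stands together with the other value shown at the limit of > 100000 nM in this assay, at which 2 of the 2 values shown sit. Compound 3 `O=C(NCc1ccco1)c1ccc(Cn2sc3ccccc3c2=O)cc1` differs from compound 2 by hydrogen in place of tert-butoxycarbonyl on an amide-type nitrogen. Among the compounds with values here, no measured step matches this change; no shift beyond the usual scatter is expected, a number no higher from compound 2 to compound 3 (the limit leaves the size open). Compound 3 is estimated at 100000 nM, between 50000 nM and 200000 nM.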

Compound 3, concentration lethal to 50% of the cells: > 100000 nM
Compound 3: only a limit was reported; the forecaster's own chance of this, stated with the estimate: 85%; the middle value lies on the limit itself.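

In this assay no step can be read from compound 1 or compound 2 to compound 3, as all three sit at one limit: the limit of > 100000 nM in this assay, at which 3 of the 3 values shown sit. The compounds shown leave open whether their toxicity differs at all in this test.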